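The compounds below may be only part of what the source reports. "The series", "measured", "known", "first", "only" and "open" are said of these compounds alone.

The measured compounds and their values in a functional assay on CHO cells for agonist activity at Free fatty acid receptor 1 (Homo sapiens); on this read-out lower numbers stand for an effect already at smaller amounts and higher numbers for an effect only at larger amounts of compound:

compound 1, `CC(CC(=O)O)c1ccc(NCc2cccc(Oc3ccccc3)c2)cc1`, gives 126 nM
compound 2, `Cc1nc(-c2ccc(C(F)(F)F)cc2)sc1CNc1ccc(C(C)CC(=O)O)cc1`, gives 58.9 nM
compound 3, `NC(=O)CCc1ccc(NCc2cccc(Oc3ccccc3)c2)cc1`, gives 51.3 nM

Compound 1 and compound 3 share one core and differ in a single place, (2-carbamoylethyl in place of 1-(carboxymethyl)ethyl on an aromatic carbon). That change gave a 2.5-fold lower number from compound 1 to compound 3 (0.39 log units; beyond the scatter). Compound 2 carries a different core; how the two cores differ is not broken down here. In this assay compound 2 shows a lower number than compound 1, while compound 2 and compound 3 lie within the scatter of each other.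

Compound 4, `Cc1nc(-c2ccc(C(F)(F)F)cc2)sc1CNc1ccc(CCC(N)=O)cc1`, has not yet been measured. It is related to compound 2 by the same change that relates compound 1 to compound 3: 2-carbamoylethyl in place of 1-(carboxymethyl)ethyl on an aromatic carbon, at the same place on the ring. Going by the values given here, from compound 2 to compound 4 a step of about the same size is expected, a 2.1-fold lower number from compound 2 to compound 4 (0.32 log units; beyond the scatter), because the one measured instance of this change, a 2.5-fold lower number from compound 1 to compound 3 (0.39 log units; beyond the scatter), went in that direction; a wider range is allowed since the two cores are not compared here. Compound 4 is therefore estimated at 28 nM, between 11 nM and 75 nM.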

Compound 4, half-maximal effective concentration: 12.9 nM
Compound 4: the middle estimate sits 2.2-fold (0.34 log units) above what was measured, and the stated range covers the measured number.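

In this assay, putting 2-carbamoylethyl in place of 1-(carboxymethyl)ethyl gave a 4.6-fold lower number from compound 2 to compound 4 (0.66 log units; beyond the scatter) and so went the same way as on the core of compound 1. The two steps agree in direction, and the gap between their sizes does not exceed what two such steps can show by scatter alone: the same change on two cores in this assay, a 2.5-fold lower number (0.39 log units; beyond the scatter) from compound 1 to compound 3 and a 4.6-fold lower number (0.66 log units; beyond the scatter) from compound 2 to compound 4, 1.9-fold (0.27 log units) apart, within the scatter of two such steps. This shows that the change carried over between these two cores in this one read-out, but two pairs do not establish a rule for other cores, and they cannot show which part of the change matters, since the branching and the end group of the chain are replaced together.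

The compounds shown leave open what an unbranched chain ending in a carboxylic acid, or a branched chain ending in a primary amide, would give on either core. They also leave open how a longer chain, a shorter chain or a nitrile in the same place would compare.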